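The source may report more compounds than this note shows. Statements on the series, on what has been measured and on what is new or still open speak of the compounds shown alone.

Measured so far:
compound 1, `O=C1NC(=O)/C(=C/C(Cc2ccccc2)c2ccc(-c3ccc4cccc(F)c4c3)[nH]c2=O)O1`: 9100 nM
compound 2, `CC(C)C(CC1NC(=O)NC1=O)c1ccc(-c2ccc3cccc(F)c3c2)[nH]c1=O`: 12300 nM

Two compounds of this series have numbers in a physicochemical assay for solubility, in phosphate buffer, measured as kinetic solubility; a higher number here means a more soluble compound, a lower number a less soluble compound. Compound 1 gives 9100 nM and compound 2 gives 12300 nM. Going by the values given here, the two values sit within the scatter of one another, so compound 2 cannot be told apart from compound 1 on these numbers; no trend is visible with only two compounds and no single-point step between them.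

Compound 3, `CC(C)C(c1ccc(-c2ccc3cccc(F)c3c2)[nH]c1=O)C1NC(=O)NC1=O`, has not yet been measured in this assay. It differs from compound 2 in one place:

2,5-dioxoimidazolidin-4-yl in place of (2,5-dioxoimidazolidin-4-yl)methyl on a saturated chain carbon bound to an aromatic carbon and a saturated chain carbon

The chain shortens by one carbon and the ring system is otherwise kept. Among the compounds with values here, with no measured step available to anchor this kind of change, the expectation is a step no larger than the scatter, leaning slightly upward.

Compound 3 is expected to give 14000 nM in this assay, within a range of 6000 nM to 35000 nM. The estimated step of a 1.1-fold higher number from compound 2 to compound 3 (0.06 log units; within the scatter) would stay within the usual scatter.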

Compound 3, solubility: 10600 nM
The estimate for compound 3 lay 1.3-fold (0.12 log units) above the measured number; the range from low to high includes it.
By their numbers in this assay, from the lowest: compounds 1, 3 and 2 (each within the scatter of the next).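

In this assay, 2,5-dioxoimidazolidin-4-yl in place of (2,5-dioxoimidazolidin-4-yl)methyl on a saturated chain carbon bound to an aromatic carbon and a saturated chain carbon gives a 1.2-fold lower number from compound 2 to compound 3 (0.06 log units; within the scatter), the first single-place step available in this series. At this place the read-out therefore does not separate the two groups, and one carbon can go without a step beyond the scatter. No measurement at hand bears on the reason for the size of this step.

On these data alone, whether a longer chain carrying the same 2,5-dioxoimidazolidin-4-yl group, or a carboxylic acid or an amine in its place, would give a step beyond the scatter remains open. Going by these compounds alone, compound 1 differs from compound 2 and compound 3 in more than one place, so no step to it can be read.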